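A few compounds are considered here, and "the series" means these few. Any claim that something is new, unique, unknown or untested is made for them only; others in the source may bear on it.

In a functional assay on MCF7 cells (Homo sapiens) for antiproliferative activity, read by CellTiter-Glo, with a stated time of 5 days (on this read-out higher numbers stand for weaker inhibition and lower numbers for stronger inhibition), compound 1 (`CC/C(=C(/c1ccc(/C=C/C(=O)O)cc1)c1ccn2nccc2c1)c1ccccc1`) gives > 500 nM as a limit and not a number. Compound 2 (`CC/C(=C(/c1ccc(/C=C/C(=O)O)cc1)c1ccn2nncc2c1)c1ccccc1`) gives > 500 nM and this too is a limit. Both values sit at the same limit (the limit of > 500 nM in this assay, at which 2 of the 2 values shown sit), so compound 2 has no readable position in the series. The change to compound 3 (`CC/C(=C(/c1ccc(/C=C/C(=O)O)cc1)c1ccc2ncsc2c1)c1ccccc1`) is a group of 9 heavy atoms (7 carbon, 1 nitrogen, 1 sulfur; one five-membered aromatic ring with 2 hetero atoms, one six-membered aromatic ring of carbon only) in place of a group of 9 heavy atoms (6 carbon, 3 nitrogen; one five-membered aromatic ring with 3 hetero atoms, one six-membered aromatic ring with 1 hetero atom), on a double-bonded chain carbon bound to an aromatic carbon and a double-bonded chain carbon and brings in the 1,3-benzothiazol-6-yl group at the same place. Among the measured compounds shown here, the only measured step at this place is a step that the two limits leave unreadable from compound 1 to compound 2 and it offers no size to carry over. With that step unreadable, compound 3 is expected to stay near the limit in this assay, with a modest shift toward stronger inhibition left open. The expected move is an at least 1.1-fold lower number from compound 2 to compound 3 (0.04 log units; that floor lies within the scatter) as an estimate only. For compound 3 the estimated value is 450 nM with 100 nM to 1500 nM as the expected range.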

Compound 3, half-maximal inhibitory concentration: > 500 nM
Compound 3: only a limit was reported (the forecaster's own chance of this, stated with the estimate: 60%); at least 1.1-fold (0.04 log units) between middle value and limit.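

In this assay compound 3 gives > 500 nM, again a limit and not a number. The steps among compound 1, compound 2 and compound 3 therefore cannot be read: the limit of > 500 nM in this assay, at which 3 of the 3 values shown sit. Still open, from the compounds shown here alone, is how the three groups at this place rank against one another.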